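Swapping cyclopropyl for oxan-4-yl on the shared core

The source may hold more compounds than are shown below. What is called first, only, known or untested is meant among the compounds shown, and "the series" means these compounds.

Measured in a physicochemical assay for solubility, at pH 2 (on this read-out lower numbers stand for lower solubility and higher numbers for higher solubility), so far:
compound 1 `CNc1nc(NCCN2CCNCC2)c2sc(-c3ccc(C(F)(F)F)cc3)cc2n1` gives 203 ug/mL
compound 2 `CNc1nc(NC(C)(C)C)c2sc(-c3ccc(C(F)(F)F)cc3)cc2n1` gives 1.6 ug/mL
compound 3 `CNc1nc(NC2CC2)c2sc(-c3ccc(C(F)(F)F)cc3)cc2n1` gives 120 ug/mL

Compound 3 belongs with the high numbers of this small set. The data show a 1.7-fold lower number from compound 1 to compound 3 (0.23 log units; within the scatter) and also a 75-fold higher number from compound 2 to compound 3 (1.88 log units; beyond the scatter) as its two gaps. Compound 4 `CNc1nc(NC2CCOCC2)c2sc(-c3ccc(C(F)(F)F)cc3)cc2n1` carries oxan-4-yl in place of cyclopropyl on a nitrogen on an aromatic ring, and the count is oxan-4-yl in place of cyclopropyl on a nitrogen on an aromatic ring for this swap. Every measured step changed this same nitrogen, and a 130-fold lower number from compound 1 to compound 2 (2.10 log units; beyond the scatter) is the largest of them. For the measured compounds named here, no measured compound carries oxan-4-yl, so the guide is loose. Compound 2 at 1.6 ug/mL in this assay shows how low a change here can go, so a moderate fall is expected rather than a drop of that size. The expected move is a 2.4-fold lower number from compound 3 to compound 4 (0.38 log units; beyond the scatter) in size. For compound 4 the estimate is 50 ug/mL with an expected range from 10 ug/mL to 180 ug/mL in this measurement.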

Compound 4, solubility: < 5 ug/mL
Compound 4 ended at the assay's limit; the forecaster's own chance of this, stated with the estimate: 3%; at least 10-fold (1.00 log units) between middle value and limit.
By their numbers in this assay, from the lowest: compound 2; then compounds 3 and 1 (each within the scatter of the next).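

In this assay compound 4 gives < 5 ug/mL, which is a limit of the assay and not a number. Among the earlier compounds only tert-butyl brought a large fall on this nitrogen, and oxan-4-yl brings one too, with an at least 24-fold lower number from compound 3 to compound 4 (1.38 log units; beyond the scatter) and an at least 40-fold lower number from compound 1 to compound 4 (1.60 log units; beyond the scatter), so an oxygen in the ring of this group does not by itself keep the number high. The step between compound 2 and compound 4 cannot be read.

Open, on these data alone, is what piperidin-4-yl, with a ring nitrogen in place of the oxygen, would give on this nitrogen.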